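Hydroxymethyl on the aryl ring of the amine-containing core

A few compounds are considered here, and "the series" means these few. Any claim that something is new, unique, unknown or untested is made for them only; others in the source may bear on it.

Among the compounds with values here, in a functional assay on HCT-116 cells (Homo sapiens) for cytotoxicity, read by sulforhodamine B assay, with a stated time of 2 days (on this read-out higher numbers stand for weaker inhibition and lower numbers for stronger inhibition), compound 2 `OC1CNCc2nc(-c3ccc(N4CCCC4)cc3)sc21` gives 25000 nM, one of only two numbers in the set, and compound 3 `OCc1cc(N2CCCC2)ccc1-c1nc2c(s1)C(O)CCC2` at 21000 nM stands within the scatter of it. Compound 1 `OC1CCCc2nc(-c3ccc(N4CCCC4)cc3)sc21` gives only a limit of the assay, > 100000 nM. Compound 4 `OCc1cc(N2CCCC2)ccc1-c1nc2c(s1)C(O)CNC2` differs from compound 2 by hydroxymethyl in place of hydrogen on an aromatic carbon. The same change on the core of compound 1 gives an at least 4.7-fold lower number from compound 1 to compound 3 (0.67 log units; beyond the scatter), a step known only as a lower bound because of the limit of > 100000 nM in this assay, at which 1 of the 3 values shown sits. On that step a lower number, at least modest, is expected for compound 4 in this assay. Compound 4 is therefore estimated at 6000 nM, between 2000 nM and 18000 nM, an expected step of a 4.2-fold lower number from compound 2 to compound 4 (0.62 log units; beyond the scatter).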

Compound 4, half-maximal inhibitory concentration: > 100000 nM
Compound 4 ended at the assay's limit (the forecaster's own chance of this, stated with the estimate: 5%); middle value at least 16-fold (1.22 log units) from the limit.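

In this assay, hydroxymethyl in place of hydrogen on an aromatic carbon, ortho to a large group, gives an at least 4.0-fold higher number from compound 2 to compound 4 (0.60 log units; beyond the scatter). The same change at this position therefore has no single direction across the two cores: the same change on two cores in this assay, an at least 4.7-fold lower number (0.67 log units; beyond the scatter) from compound 1 to compound 3 and an at least 4.0-fold higher number (0.60 log units; beyond the scatter) from compound 2 to compound 4, at least 19-fold (1.27 log units) apart, beyond the scatter of two such steps. The new step is only a bound, with compound 4 standing at a limit of the assay: the limit of > 100000 nM in this assay, at which 2 of the 4 values shown sit.

Going by these compounds, whether a methoxy or an aminomethyl group on this aromatic carbon would follow either direction stays open. On these data alone, the full size of both steps also stays open, each being known only as a bound.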